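A few compounds are considered here, and "the series" means these few. Any claim that something is new, unique, unknown or untested is made for them only; others in the source may bear on it.

Compound 2, with the structure `O=C(Nc1ccc(-c2cn[nH]c2)cc1F)C1COc2ccccc2C1`, gives 4 nM in an assay on isolated protein for inhibition of Rho-associated protein kinase 2 (Homo sapiens); on this read-out higher numbers stand for weaker inhibition and lower numbers for stronger inhibition. On that read-out compound 1, with the structure `COc1cc(NC(=O)C2COc3ccccc3C2)ccc1-c1cn[nH]c1`, gives 4 nM, level with compound 2 at the digits printed, and compound 3, with the structure `COc1cc(-c2cn[nH]c2)c(F)cc1NC(=O)C1COc2ccccc2C1`, gives 5 nM, a number within the scatter of the other two. All three compounds share the same amide-linked core and the 1H-pyrazol-4-yl group, and the three numbers lie close together.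

Compound 4, with the structure `COc1cc(NC(=O)C2COc3ccccc3C2)c(F)cc1-c1cn[nH]c1`, has not yet been measured in this assay. It differs from compound 2 by methoxy in place of hydrogen on an aromatic carbon. Compound 3 already carries a methoxy group together with a fluoro group on the same aromatic ring, and its value in this assay sits within the scatter of compound 2. On that basis compound 4 is expected to show a step of no change at the digits printed from compound 2 to compound 4 (within the scatter), which is no step beyond the scatter. Compound 4 is therefore estimated at 4 nM, with a range from 2 nM to 10 nM.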

Compound 4, half-maximal inhibitory concentration: 17 nM
Compound 4: middle estimate off by 4.3-fold (0.63 log units), on the low side; measured number above the stated range.
By their numbers in this assay, from the lowest: compounds 1, 2 and 3 (each within the scatter of the next); then compound 4.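

In this assay, methoxy on the aromatic carbon ortho to the 1H-pyrazol-4-yl group and para to the fluoro group weakens inhibition when fluoro is already present, giving a 4.3-fold higher number from compound 2 to compound 4 (0.63 log units; beyond the scatter). Read the other way, fluoro in place of hydrogen on an aromatic carbon, with that methoxy already present, gives a 4.3-fold higher number from compound 1 to compound 4 (0.63 log units; beyond the scatter), so each group is tolerated alone, yet the number rises once both stand in these places. Compound 3, which carries both groups in other places, goes against any reading that the pair itself raises the number, with 5 nM.

Nothing among the available data explains this rise. As far as these compounds go, it remains open whether ethoxy in place of the methoxy, or chloro in place of the fluoro, would give the same rise.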